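The source may hold more compounds than are shown below. What is called first, only, known or untested is meant among the compounds shown, and "the series" means these compounds.

Measured in a functional assay on A549 cells (Homo sapiens) for antiproliferative activity, read by sulforhodamine B assay, with a stated time of 48 h; a lower number here means a stronger inhibitor, a higher number a weaker inhibitor:
- compound 1 `COc1cc(C(=O)/C=C\Nc2ccc(-c3nc4cc(OC)c(OC)c(OC)c4s3)cc2C)cc([N+](=O)[O-])c1OC`: 17400 nM
- compound 2 `COc1cc(OC)c2sc(-c3ccc(N/C=C\C(=O)c4cc(OC)c(OC)c([N+](=O)[O-])c4)c(C)c3)nc2c1`: 15400 nM
- compound 3 `COc1cc(C(=O)/C=C\Nc2ccc(-c3nc4cc(OC)c(OC)c(OC)c4s3)cc2)cc([N+](=O)[O-])c1OC`: 11800 nM

Compound 1 stands level with the other two, since neither of its steps leaves the scatter: a 1.1-fold lower number from compound 1 to compound 2 (0.05 log units; within the scatter) and a 1.5-fold lower number from compound 1 to compound 3 (0.17 log units; within the scatter). Compound 4 `COc1cc(C(=O)/C=C\Nc2ccc(-c3nc4cc(OC)c(OC)c(OC)c4s3)cc2C)cc(OC)c1OC` has methoxy in place of nitro on an aromatic carbon, ortho to a methoxy group: methoxy in place of nitro on an aromatic carbon. Neither measured step touches the nitro group, so they bear on this change only indirectly, showing that two other edits left this assay within the scatter. The data give no direction for this swap, and no shift beyond the scatter is expected. The expected step is a 1.7-fold lower number from compound 1 to compound 4 (0.24 log units; within the scatter). For compound 4 the estimated value is 10000 nM, with an expected range of 2500 nM to 30000 nM.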

Compound 4, half-maximal inhibitory concentration: 23300 nM
For compound 4 the middle estimate is 2.3-fold (0.37 log units) below the measured one; low and high end bracket the measured number.
By their numbers in this assay, from the lowest: compounds 3, 2, 1 and 4 (each within the scatter of the next).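

Methoxy in place of nitro, ortho to a methoxy group, gives a 1.3-fold higher number from compound 1 to compound 4 (0.13 log units; within the scatter) in this assay, so this position takes the swap without a shift beyond the scatter. The earlier steps shown here left the nitro group in place; this one shows that compound 4 stays level with compound 1 without it. No measurement on hand accounts for this result.

Going by these compounds, whether an amine or a carboxylic acid at this position would move the number beyond the scatter stays open. The same holds for a longer alkoxy chain in place of methoxy.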